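Adding a Methoxy Group to a Phenolic Ketone

The source may report more compounds than this note shows. Statements on the series, on what has been measured and on what is new or still open speak of the compounds shown alone.

Compound 1, `COc1ccc(C(=O)CCc2ccc(OC)c(OC)c2)c(O)c1`: 67.5%
Compound 2, `COc1cc(CCC(=O)c2cccc(O)c2)ccc1O`: 91%

Of the compounds shown here, two have been measured in an ADME assay on RAW264.7 cells (Mus musculus) for cytotoxicity, read by MTT assay, with a stated time of 24 h, tested at 10 ug/mL; on this read-out higher numbers stand for a weaker effect at the one concentration tested and lower numbers for a stronger effect. In this assay compound 1 gives 67.5%, the lowest of the two numbers. Compound 2 gives 91%, a number that lies beyond the scatter above that of compound 1, so compound 1 shows the stronger effect of the measured pair.

Compound 3, `COc1ccc(C(=O)CCc2ccc(OC)c(OC)c2OC)c(O)c1`, has not yet been measured. It differs from compound 1 in one place: methoxy in place of hydrogen on an aromatic carbon. The incoming group sits on an aromatic carbon of a six-membered aromatic ring of carbon only, ortho to a large group, ortho to a methoxy group and meta to a methoxy group. Going by the values given here, no two measured compounds differ from each other in this way, so the change has no precedent among the numbers at hand. For that reason the expected step in this assay is small, none beyond the scatter, in either direction. Compound 3 is estimated at 65%, with a range from 45% to 85%. This corresponds to an expected step of a number 2.5 percentage points lower from compound 1 to compound 3 (within the scatter).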

Compound 3, a percentage reported as activity, at one concentration (the size of the read-out at that concentration, not a potency): 94%
The estimate for compound 3 lay 29 percentage points below the measured number; the measured number lies above the stated range.
By their numbers in this assay, from the lowest: compound 1; then compounds 2 and 3 (each within the scatter of the next).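

Putting methoxy in place of hydrogen on this aromatic carbon, ortho to a large group, ortho to a methoxy group and meta to a methoxy group, gives a number 26.5 percentage points higher from compound 1 to compound 3 (beyond the scatter) in this assay at the one concentration tested. Since a higher number stands for a weaker effect, this single change weakens the effect of compound 1, so this position is not a silent spot on the molecule, and an added group of 2 heavy atoms here is enough to move the read-out past the usual scatter. The compounds at hand offer no measurement that explains why this step occurs.

This is one change at one position, read at a single concentration, so it gives no potency and no rule for other positions or other groups. Going by these compounds, whether an amine, a carboxylic acid or a single fluorine atom on this same aromatic carbon would move the number in the same direction stays open, as does whether methoxy on a different carbon of this ring would do so.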